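The compounds below may be only part of what the source reports. "The series", "measured", "known", "first", "only" and "open" are said of these compounds alone.

Measured compounds:
compound 1 `COc1cc(N2C(N)=C(C#N)C(c3c(OC)ccc4ccccc34)C3=C2CC(C)(C)CC3=O)cc(OC)c1OC`, 5% in a functional assay on Ehrlich cells (Mus musculus) for cytotoxicity, tested at 25 ug/mL; a lower number here means a weaker effect, a higher number a stronger effect of the compound at the concentration tested
compound 2 `COc1cc(N2C(N)=C(C#N)C(c3ccc(Cl)cc3Cl)C3=C2CC(C)(C)CC3=O)cc(OC)c1OC`, 55% in this assay

Compound 2 stands highest of the two numbers shown in this assay; its nearest neighbour is compound 1, which gives 5%, a number well apart from it. Among the measured compounds shown here, the single measured step, a number 50 percentage points higher from compound 1 to compound 2 (beyond the scatter), shows how much the aryl group on the saturated ring carbon matters for this read-out.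

Compound 3 `COc1ccccc1C1C(C#N)=C(N)N(c2cc(OC)c(OC)c(OC)c2)C2=C1C(=O)CC(C)(C)C2` has not been measured. It differs from compound 2 in one place: 2-methoxyphenyl in place of 2,4-dichlorophenyl on a saturated ring carbon. For the measured compounds named here, the only step that bears on this change is the one from compound 1 to compound 2, where a 2-methoxynaphthalen-1-yl group was exchanged for 2,4-dichlorophenyl and the activity rose by a large margin. Compound 3 now carries 2-methoxyphenyl in that same position, moving away from the 2,4-dichlorophenyl that accompanied the highest number. A step downward, beyond the scatter, is therefore expected, though not necessarily as deep as compound 1. Compound 3 is estimated at 22%, within 4% to 45%, which would mean an expected step of a number 33 percentage points lower from compound 2 to compound 3 (beyond the scatter).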

Compound 3, a percentage reported as activity, at one concentration (the size of the read-out at that concentration, not a potency): 65%
Beside the measured number, compound 3's estimate is 43 percentage points below it; the measured number lies above the stated range.
By their numbers in this assay, from the lowest: compound 1; then compounds 2 and 3 (each within the scatter of the next).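

In this assay, the exchange of 2,4-dichlorophenyl for 2-methoxyphenyl on the saturated ring carbon gives a number 10 percentage points higher from compound 2 to compound 3 (within the scatter), so this read-out does not separate the two groups, even though they differ in their substituents and only the entering group carries a hydrogen-bond acceptor. The comparison with the 2-methoxynaphthalen-1-yl group gives a number 60 percentage points higher from compound 1 to compound 3 (beyond the scatter), which shows that a methoxy group on the aryl ring occurs with both the low and the high numbers and that the low number of compound 1 cannot be tied to the methoxy group alone. Among these three compounds, the two carrying a single six-membered aromatic ring at this position stand together, apart from compound 1, and nothing given here accounts for that difference.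

The compounds shown leave open whether an unsubstituted phenyl or an unsubstituted naphthalen-1-yl group would stand with compound 3 or with compound 1. They also leave open how a 4-methoxyphenyl or a pyridyl group would read at this position.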